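A Fourth Methoxy Group Added to Compound 3

This account rests on a few compounds, and the source may have more. Where it says the series, first, only, none or still open, it means among the compounds named here.

Of the compounds shown here, three sharing one core have been measured in a functional assay on SK-MEL-5 cells (Homo sapiens) for cytotoxicity, read by sulforhodamine B assay, with a stated time of 48 h, tested at 0.01 uM; on this read-out lower numbers stand for a stronger effect and higher numbers for a weaker effect at the one concentration tested. Compound 1 `COc1cc(-c2cc(/C=C/C(=O)c3ccc(Cl)c(Cl)c3)[nH]n2)cc(OC)c1OC` gives 98%; compound 2 `COc1ccc(-c2cc(/C=C/C(=O)c3cc(OC)c(OC)c(OC)c3)[nH]n2)cc1OC` gives 101%; compound 3 `COc1ccc(C(=O)/C=C/c2cc(-c3cc(OC)c(OC)c(OC)c3)n[nH]2)cc1OC` gives 97%. Among the measured compounds shown here, compound 3 thus stands inside the usual scatter of both of the others, and the one step that changes a single place, a number 1 percentage points lower from compound 1 to compound 3 (within the scatter), was likewise within the scatter. Compound 4 `COc1cc(C(=O)/C=C/c2cc(-c3cc(OC)c(OC)c(OC)c3)n[nH]2)cc(OC)c1OC` is not yet measured. It differs from compound 3 by methoxy in place of hydrogen on an aromatic carbon, placed on an aromatic carbon of a six-membered aromatic ring of carbon only, ortho to a methoxy group and meta to a large group. For the measured compounds named here, the only measured step touching that ring, a number 1 percentage points lower from compound 1 to compound 3 (within the scatter), moved nothing beyond the scatter, and compound 2, which carries a trimethoxyphenyl on its carbonyl carbon, also gives 101%. The expected step from compound 3 to compound 4 is therefore a number 2 percentage points higher from compound 3 to compound 4 (within the scatter), nothing beyond the scatter. Compound 4 is estimated at 99%, in a range from 90% to 108%.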

Compound 4, a percentage reported as activity, at one concentration (the size of the read-out at that concentration, not a potency): 96%
Estimate against measurement, compound 4: 3 percentage points above; the measured number falls inside the stated range.
By their numbers in this assay, from the lowest: compounds 4, 3, 1 and 2 (each within the scatter of the next).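

In this assay the direct addition of methoxy in place of hydrogen at this position, ortho to a methoxy group and meta to a large group, gives a number 1 percentage points lower from compound 3 to compound 4 (within the scatter) and so leaves the read-out unchanged within the scatter. The same kind of change made elsewhere in the molecule gives a number 5 percentage points lower from compound 2 to compound 4 (within the scatter) and is also within the scatter, so neither of the two places tested for this addition shows an effect at the one concentration used. Nothing available explains this result.

On these data alone, it remains open whether an amine, a carboxylic acid or a longer chain on this aromatic carbon would move the read-out beyond the scatter. With all four compounds lying within the scatter of one another, these data also cannot say whether this position matters at all in this assay.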